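The compounds below may be only part of what the source reports. "The series", "measured", "known", "first", "only" and "open" are said of these compounds alone.

Measured in a functional assay on K562 cells (Homo sapiens) for antiproliferative activity, read by MTT assay; a lower number here means a stronger inhibitor, a higher number a weaker inhibitor:
- compound 1 `Cc1ccccc1/C(=N/NC(=S)NCCCCCC(=O)NO)c1ccccc1`: 3510 nM
- compound 2 `C/C(=N\NC(=S)NCCCCCC(=O)NO)c1ccc(Br)cc1`: 960 nM

Of these two, compound 2 has the lower number, meaning the stronger inhibitor, and the gap to compound 1 lies beyond the usual scatter. The next compound, compound 3 `COc1cccc(/C(C)=N/NC(=S)NCCCCCC(=O)NO)c1`, has 3-methoxyphenyl in place of 4-bromophenyl on a carbon with a double bond to nitrogen. Within the data shown here, no two measured compounds differ in one place only, so the data show nothing directly about a swap of this kind. The expectation in this assay is therefore a modest rise in the number, toward a weaker inhibitor, and it may stay within the scatter. The estimated change is a 1.6-fold higher number from compound 2 to compound 3 (0.19 log units; within the scatter). Compound 3 is expected at 1500 nM, with an estimated range from 500 nM to 4500 nM.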

Compound 3, half-maximal inhibitory concentration: 1910 nM
The estimate for compound 3 lay 1.3-fold (0.10 log units) below the measured number, and the stated range covers the measured number.
By their numbers in this assay, from the lowest: compounds 2, 3 and 1 (each within the scatter of the next, the first and the last beyond it).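

In this assay, among these compounds, compounds 2 and 3 are the only pair here that differ in one place, and putting 3-methoxyphenyl in place of 4-bromophenyl on a carbon with a double bond to nitrogen gives a 2.0-fold higher number from compound 2 to compound 3 (0.30 log units; within the scatter). This position therefore accepts an exchange of bromine for a group that brings one hydrogen-bond acceptor, with no difference that can be told from repeated-measurement scatter. Nothing available explains why these two groups give readings this close.

As far as these compounds go, the swap alters both the group on the ring and its numbered place, so the effect of each alone remains open, and 4-methoxyphenyl or 3-bromophenyl would separate them. Also open, from the compounds shown here alone, is how this position responds to a group of another kind, such as an amine or a carboxylic acid on the ring.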